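Lengthening the chain from compound 3 to compound 4

The source may report more compounds than this note shows. Statements on the series, on what has been measured and on what is new or still open speak of the compounds shown alone.

Tested in a functional assay on A-375 cells (Homo sapiens) for antiproliferative activity, read by sulforhodamine B assay, with a stated time of 48 h (on this read-out higher numbers stand for weaker inhibition and lower numbers for stronger inhibition), so far:
Compound 1 `CCCCCCCCCCNC(=O)c1c[nH]c(-c2ccccc2)n1` gives > 30000 nM (a limit)
Compound 2 `CCCCCCCCCCCCNC(=O)c1c[nH]c(-c2ccccc2)n1` gives > 30000 nM (a limit)
Compound 3 `CCCCCCCCCCCCCCCCNC(=O)c1c[nH]c(-c2ccccc2)n1` gives 16500 nM (a number)

Among the measured compounds shown here, compound 3, at 16500 nM in this assay, holds the only number. For compound 1 and compound 2 there is only the limit of > 30000 nM in this assay, at which 2 of the 3 values shown sit, and no number.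

Compound 4 `CCCCCCCCCCCCCCCCCCNC(=O)c1c[nH]c(-c2ccccc2)n1` differs from compound 3 by ethyl in place of hydrogen on a saturated chain carbon, ten or more bonds along the chain from an amide-type nitrogen on the chain. The same ethyl change appears as a step that the two limits leave unreadable from compound 1 to compound 2 and so gives no size. The longer additions, an at least 1.8-fold lower number from compound 1 to compound 3 (0.25 log units; that floor lies within the scatter) and an at least 1.8-fold lower number from compound 2 to compound 3 (0.25 log units; that floor lies within the scatter), point towards lower numbers, though only as floors. A modest further fall is therefore expected in this assay, possibly none beyond the scatter. The estimated step is a 1.5-fold lower number from compound 3 to compound 4 (0.18 log units; within the scatter) and no more is claimed. For compound 4 the expected value is 11000 nM, with an estimated range from 4500 nM to 27000 nM on repeat measurement.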

Compound 4, half-maximal inhibitory concentration: 20700 nM
Estimate against measurement, compound 4: 1.9-fold (0.27 log units) below, and the stated range covers the measured number.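

In this assay, the ethyl change now has a readable size, a 1.3-fold higher number from compound 3 to compound 4 (0.10 log units; within the scatter), so at these chain lengths it brings no change beyond the scatter. The longer additions still give only floors, an at least 1.4-fold lower number from compound 2 to compound 4 (0.16 log units; that floor lies within the scatter) and an at least 1.4-fold lower number from compound 1 to compound 4 (0.16 log units; that floor lies within the scatter). Hexyl in place of hydrogen on a saturated chain carbon now appears twice: the same change on two cores in this assay, an at least 1.8-fold lower number (0.25 log units; that floor lies within the scatter) from compound 1 to compound 3 and an at least 1.4-fold lower number (0.16 log units; that floor lies within the scatter) from compound 2 to compound 4; the limit leaves it open whether they differ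

Going by these compounds, the true size of these longer steps stays open, as the shorter chains give no number: the limit of > 30000 nM in this assay, at which 2 of the 4 values shown sit. Also open is whether a longer chain, or an amine at the chain end, would move the number beyond the scatter.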